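The source may report more compounds than this note shows. Statements on the series, on what has been measured and on what is new or still open speak of the compounds shown alone.

In a functional assay on HEY cells (Homo sapiens) for cytotoxicity, read by MTT assay, with a stated time of 72 h (on this read-out higher numbers stand for weaker inhibition and lower numbers for stronger inhibition), compound 1 `N[C@H]1CC[C@H](Nc2c(C(=O)NCc3ccc(Cl)cc3Cl)nc(Br)c3cccnc23)CC1` gives 5000 nM and compound 2 `N[C@H]1CC[C@H](Nc2c(C(=O)NCc3ccc(Cl)cc3)nc(Br)c3cccnc23)CC1` gives 1000 nM, which is a 5.0-fold lower number from compound 1 to compound 2 (0.70 log units; beyond the scatter). Compound 3 `COC(=O)c1nc(Br)c2cccnc2c1N[C@H]1CC[C@H](N)CC1` gives > 20000 nM, the only limit of the assay among the three and not a number. Compound 4 `N[C@H]1CC[C@H](Nc2c(C(=O)NCc3ccccn3)nc(Br)c3cccnc23)CC1` carries ((pyridin-2-yl)methyl)amino in place of methoxy on a carbonyl carbon. Two measured steps run the opposite way, with methoxy entering: an at least 4.0-fold higher number from compound 1 to compound 3 (0.60 log units; beyond the scatter), at least modest, and an at least 20-fold higher number from compound 2 to compound 3 (1.30 log units; beyond the scatter), large. A clearly lower number, of modest to large size, is therefore expected in this assay. What is expected is an at least 6.6-fold lower number from compound 3 to compound 4 (0.82 log units; beyond the scatter). Compound 4 is estimated at 3000 nM, with an expected range from 700 nM to 15000 nM.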

Compound 4, half-maximal inhibitory concentration: > 20000 nM
Compound 4 ended at the assay's limit; the forecaster's own chance of this, stated with the estimate: 15%; middle value at least 6.6-fold (0.82 log units) away from the limit.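

Replacing methoxy with an amide is not enough on its own to give a measurable value in this assay, as the aryl group on the chain matters: pyridin-2-yl in place of the chlorinated phenyl groups on the saturated chain carbon gives an at least 20-fold higher number from compound 2 to compound 4 (1.30 log units; beyond the scatter) and an at least 4.0-fold higher number from compound 1 to compound 4 (0.60 log units; beyond the scatter). The step between compound 3 and compound 4 cannot be read, since both values are limits: the limit of > 20000 nM in this assay, at which 2 of the 4 values shown sit.

On these data alone, it remains open whether a plain phenyl or a chloro-bearing pyridin-2-yl group on that carbon would keep the activity of compound 2 or fall to the limit of compound 4.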